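From Methoxy to Methylpiperazine on the Shared Core

The compounds below may be only part of what the source reports. "The series", "measured", "known", "first", "only" and "open" are said of these compounds alone.

Measured so far in a functional assay on the whole organism for inhibition, with Rattus norvegicus as the target; on this read-out higher numbers stand for an effect only at larger amounts of compound and lower numbers for an effect already at smaller amounts:
Compound 1 `CN1CCN(c2cccc(NC(=O)c3nn[nH]n3)c2C#N)CC1` gives 0.02 mg/kg
Compound 2 `COc1cccc(NC(=O)c2nn[nH]n2)c1C(N)=O` gives 0.1 mg/kg

Of these two results, compound 2 has the higher number, and its gap to compound 1 lies beyond the usual scatter. Higher numbers in this assay mean that more compound is needed. Compound 2 is the less potent of the pair. Among the measured compounds shown here, no two measured compounds differ in only one place, so no measured step isolates a single structural change.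

Compound 3 `CN1CCN(c2cccc(NC(=O)c3nn[nH]n3)c2C(N)=O)CC1` keeps the carbamoyl group of compound 2 but has 4-methylpiperazin-1-yl in place of methoxy on an aromatic carbon, ortho to a carbamoyl group (4-methylpiperazin-1-yl in place of methoxy on an aromatic carbon). Compound 1 (0.02 mg/kg) also carries 4-methylpiperazin-1-yl, but it has a nitrile where compound 3 has the carbamoyl group. This single comparison supports only a cautious expectation of a moderate move towards a lower number in this assay. The expected change is a 2.5-fold lower number from compound 2 to compound 3 (0.40 log units; beyond the scatter), and this remains uncertain. For compound 3 the estimated value is 0.04 mg/kg (expected range 0.01 mg/kg to 0.2 mg/kg).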

Compound 3, dose for half-maximal effect: 0.01 mg/kg
Compound 3: middle estimate off by 4.0-fold (0.60 log units), on the high side; low and high end bracket the measured number.
By their numbers in this assay, from the lowest: compounds 3 and 1 (each within the scatter of the next); then compound 2.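

In this assay, the aromatic carbon ortho to a carbamoyl group now has a single change that can be read: with the carbamoyl group held fixed, 4-methylpiperazin-1-yl in place of methoxy gives a 10-fold lower number from compound 2 to compound 3 (1.00 log units; beyond the scatter) and so lies beyond the usual scatter. With 4-methylpiperazin-1-yl held fixed, carbamoyl in place of cyano on an aromatic carbon gives a 2.0-fold lower number from compound 1 to compound 3 (0.30 log units; within the scatter) and stays within the scatter, so this read-out does not tell these two groups apart in this pair. Nothing measured here bears on why either step came out as it did.

The compounds shown leave open whether the step belongs to 4-methylpiperazin-1-yl in particular or would carry over to another replacement for methoxy, such as morpholine or a dimethylamino group. They also leave open how a carboxylic acid in place of the carbamoyl group would read in this assay, and whether the step from methoxy to 4-methylpiperazin-1-yl would have the same size with a nitrile on the shared core.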